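A Pyridinyloxy Amide Replaces a Cyclohexyl Group

A few compounds are considered here, and "the series" means these few. Any claim that something is new, unique, unknown or untested is made for them only; others in the source may bear on it.

Four compounds share one core. Compound 1 `C=CCNC(=O)n1c(-c2ccc(OC)cc2)cc(=O)c2c(OC)cc(OC)cc21` was tested in a functional assay on SEM cells (Homo sapiens) for antiproliferative activity, with a stated time of 72 h (a lower number here means that less compound is needed, a higher number that more compound is needed for the effect), and gives 12000 nM. Compound 2 `COc1ccc(-c2c(Cl)c(=O)c3c(OC)cc(OC)cc3n2S(=O)(=O)c2ccc(OC)cc2)cc1` has in this assay only the entry "not determined" (no result reported), so no result is recorded for it. Compound 3 `COc1cc(OC)c2c(=O)cc(C(=O)Nc3ccc(C4CCCCC4)cc3)[nH]c2c1` likewise has in this assay only the entry "not determined" (no result reported), so it cannot be placed against compound 1, and compound 2 is the other entry without a value. Compound 4 `COc1cc(OC)c2c(=O)cc(C(=O)Nc3ccc(Oc4cccnc4)cc3)[nH]c2c1` differs from compound 3 in one place: (pyridin-3-yl)oxy in place of cyclohexyl on an aromatic carbon. For the measured compounds named here, with no measured pair to anchor the size or direction of this change, the expectation for compound 4 rests on the single value of compound 1 alone, with wide uncertainty. Compound 4 is estimated to give 3000 nM in this assay, within a range from 300 nM to 30000 nM.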

Compound 4, half-maximal effective concentration: > 32100 nM
Compound 4 ended at the assay's limit; the forecaster's own chance of this, stated with the estimate: 25%; middle value at least 10-fold (1.02 log units) from the limit.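

For the compounds shown here, compound 3 has no number in this assay, so no step to compound 4 can be read. Compound 4 gives > 32100 nM, which is a limit of the assay and not a number. The compounds shown leave open whether (pyridin-3-yl)oxy in place of cyclohexyl changes the result at all.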